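Amide analogue with a 3-chloro-4-fluorophenyl group

The source may report more compounds than this note shows. Statements on the series, on what has been measured and on what is new or still open speak of the compounds shown alone.

Of the compounds shown here, two sharing one core have been tested in a functional assay on Raji cells (Homo sapiens) for antiproliferative activity, read by CCK-8 assay, with a stated time of 72 h, tested at 40 uM; a lower number here means less inhibition, a higher number more inhibition at the concentration tested (going by the name of the read-out). Compound 1 `CN1CCN(c2ccc(Nc3nc(-c4cccc(NC(=O)c5ccc(F)c(Cl)c5)c4)sc3C(=O)O)cc2)CC1` carries an acid on the core and a 3-chloro-4-fluorophenyl group on the amide carbonyl; in this assay compound 1 gives 87.9%. Compound 2 `CN1CCN(c2ccc(Nc3nc(-c4cccc(NC(=O)c5ccc(Cl)cc5)c4)sc3C(N)=O)cc2)CC1` carries a primary amide on the core and a 4-chlorophenyl group on the amide carbonyl; in this assay compound 2 gives 92.6%. The two numbers lie within the usual scatter of each other, so the inhibition in this assay is level between them.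

Compound 3 `CN1CCN(c2ccc(Nc3nc(-c4cccc(NC(=O)c5ccc(F)c(Cl)c5)c4)sc3C(N)=O)cc2)CC1` differs from compound 2 in one place: 3-chloro-4-fluorophenyl in place of 4-chlorophenyl on a carbonyl carbon. Among the compounds with values here, no measured pair shows this change alone. Since the same group is present in compound 1, which gives 87.9%, no step beyond the scatter is expected, and the change from compound 2 to compound 3 is estimated as a number 2.6 percentage points lower from compound 2 to compound 3 (within the scatter). Compound 3 is therefore expected to give about 90%, with a likely range from 82% to 96%.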

Compound 3, a percentage reported as inhibition, at one concentration (the size of the read-out at that concentration, not a potency): 94.4%
Estimate against measurement, compound 3: 4.4 percentage points below; low and high end bracket the measured number.
By their numbers in this assay, from the lowest: compounds 1, 2 and 3 (each within the scatter of the next).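

Within the data shown here, the pair compound 2 and compound 3 is the first to show this change alone, with 3-chloro-4-fluorophenyl in place of 4-chlorophenyl on a carbonyl carbon, and in this assay it gives a number 1.8 percentage points higher from compound 2 to compound 3 (within the scatter) and so leaves the two groups level. Compound 3 also isolates a second change on the core, amino in place of hydroxy on a carbonyl carbon, which gives a number 6.5 percentage points higher from compound 1 to compound 3 (within the scatter) and so leaves the primary amide and the acid level as well. No measurement at hand offers an explanation for either result.

Going by these compounds, whether a plain phenyl on the amide carbonyl, or a nitrile or methyl ester on the core, would shift the inhibition remains open. Each number also reports inhibition at one concentration, so these level results leave any difference in potency among the three compounds unresolved.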